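Amide-to-urea change on the anilide side of the series

This account rests on a few compounds, and the source may have more. Where it says the series, first, only, none or still open, it means among the compounds named here.

Measured compounds:
compound 1, `COc1cc(-c2nn(-c3cccc(NC(=O)Nc4cc(C(F)(F)F)cc(C(F)(F)F)c4)c3)cc2-c2ccncc2)ccc1Cl`: 12000 nM
compound 2, `COc1cc(-c2nn(-c3cccc(NC(=O)c4cccc(C(F)(F)F)c4)c3)cc2-c2ccncc2)ccc1Cl`: > 50000 nM
compound 3, `O=C(Nc1cccc(-n2cc(-c3ccncc3)c(-c3ccc(Cl)c(O)c3)n2)c1)Nc1cc(C(F)(F)F)cc(C(F)(F)F)c1`: 4700 nM

In a functional assay on OVCAR-5 cells (Homo sapiens) for inhibition, read by sulforhodamine B assay, with a stated time of 48 h (on this read-out higher numbers stand for lower toxicity in this test and lower numbers for higher toxicity in this test), compound 2 gives only a limit, > 50000 nM, so no number is known for it (the limit of > 50000 nM in this assay, at which 1 of the 3 values shown sits). For the measured compounds named here, compound 1 gives 12000 nM in this assay and compound 3 gives 4700 nM; the one measured step between them, a 2.6-fold lower number from compound 1 to compound 3 (0.41 log units; beyond the scatter), concerns a change on an oxygen on an aromatic ring and does not touch the part altered here.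

Compound 4, `COc1cc(-c2nn(-c3cccc(NC(=O)Nc4ccc(Cl)c(C(F)(F)F)c4)c3)cc2-c2ccncc2)ccc1Cl`, is not yet measured. It differs from compound 2 in one place: (4-chloro-3-(trifluoromethyl)phenyl)amino in place of 3-(trifluoromethyl)phenyl on a carbonyl carbon. Through this change compound 4 carries an amino group on the carbonyl carbon, as compound 1 and compound 3 do, whereas compound 2 does not. Going by the values given here, no measured step covers this change, so the expectation rests on the two measured ureas, compound 1 and compound 3, rather than on a step.

Compound 4 is expected to give a number in this assay rather than a limit, near 12000 nM, within 4000 nM to 40000 nM. Against the limit of compound 2 this estimate means a step of an at least 4.1-fold lower number from compound 2 to compound 4 (0.61 log units; beyond the scatter), though its size is uncertain since compound 2 gives no number.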

Compound 4, concentration lethal to 50% of the cells: > 32500 nM
Compound 4 gave a limit, no number (the forecaster's own chance of this, stated with the estimate: 20%); at least 2.7-fold (0.43 log units) between middle value and limit.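

Compound 4 gives only a limit in this assay, > 32500 nM. Compound 2 also gives only a limit, > 50000 nM, so the step between compound 2 and compound 4 cannot be read. The compounds shown leave open whether (4-chloro-3-(trifluoromethyl)phenyl)amino in place of 3-(trifluoromethyl)phenyl on a carbonyl carbon changes the read-out at all.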